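The source may hold more compounds than are shown below. What is called first, only, known or untested is meant among the compounds shown, and "the series" means these compounds.

Measured in a toxicity assay on L02 cells (Homo sapiens) for cytotoxicity, read by MTT assay, with a stated time of 72 h; a lower number here means a stronger inhibitor, a higher number a weaker inhibitor:
compound 1 `O=C1c2c[n+]([O-])c3ccccc3c2C(=O)c2c1c1ccccc1n2Cc1cn(C[C@H](O)CO)nn1` gives 1130 nM
compound 2 `O=C1c2c[n+]([O-])c3ccccc3c2C(=O)c2c1c1ccccc1n2CCN1CCCC1` gives 930 nM
compound 3 `CN(C)CCCCn1c2c(c3ccccc31)C(=O)c1c[n+]([O-])c3ccccc3c1C2=O` gives 300 nM

Compound 3 holds the lowest of these numbers, and the other two lie beyond the scatter from it. The next structure, compound 4 `CN1CCN(CCCCCn2c3c(c4ccccc42)C(=O)c2c[n+]([O-])c4ccccc4c2C3=O)CC1`, differs from it as follows: (4-methylpiperazin-1-yl)methyl in place of dimethylamino on a saturated chain carbon, four bonds along the chain from an aromatic nitrogen. In words, this is (4-methylpiperazin-1-yl)methyl in place of dimethylamino on a saturated chain carbon, four bonds along the chain from an aromatic nitrogen.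

The closest measured precedent is a 3.1-fold lower number from compound 2 to compound 3 (0.49 log units; beyond the scatter), where 2-(dimethylamino)ethyl replaced pyrrolidin-1-yl. Read in reverse, it suggests a higher number for compound 4, since a saturated ring returns. The step of a 3.8-fold lower number from compound 1 to compound 3 (0.58 log units; beyond the scatter) is of similar size, whereas a 1.2-fold lower number from compound 1 to compound 2 (0.08 log units; within the scatter) gives little guidance. Among the compounds with values here, no measured pair separates the effect of the ring from that of chain length, so the expectation is loose. In this assay the expected result is a 1.8-fold higher number from compound 3 to compound 4 (0.26 log units; within the scatter), a modest move towards a weaker inhibitor. Compound 4 is estimated at 550 nM, with an expected range of 200 nM to 1400 nM.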

Compound 4, half-maximal inhibitory concentration: 1640 nM
The estimate for compound 4 lay 3.0-fold (0.47 log units) below the measured number, outside the stated range (above it).
By their numbers in this assay, from the lowest: compound 3; then compounds 2, 1 and 4 (each within the scatter of the next).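

In this assay, (4-methylpiperazin-1-yl)methyl in place of dimethylamino, on a saturated chain carbon, four bonds along the chain from an aromatic nitrogen, gives a 5.5-fold higher number from compound 3 to compound 4 (0.74 log units; beyond the scatter) and is not tolerated as well as the open-chain amine. With a 1.8-fold higher number from compound 2 to compound 4 (0.25 log units; within the scatter) and a 1.5-fold higher number from compound 1 to compound 4 (0.16 log units; within the scatter) both within the scatter, compound 3 alone now stands apart from the other three. Compound 2 and compound 4 both end in a saturated ring and lie within the scatter of each other, but compound 1 goes against tying this to that ring, as it carries a triazole and shares the same band.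

The ring and the chain length change together in this step, and no evidence at hand accounts for the result.

Still open, as far as these compounds go, is whether a morpholin-4-yl group on the same chain would behave like the 4-methylpiperazin-1-yl group or like dimethylamino.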